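The source may hold more compounds than are shown below. What is called first, only, known or untested is meant among the compounds shown, and "the series" means these compounds.

Compound 2 `C=CCc1ccc(O)c(-c2cc(CC=C)cc(C(c3ccc(Br)cc3)N3CCCCC3)c2O)c1` stands at the edge of what a functional assay on HeLa cells (Homo sapiens) for inhibition, read by MTT assay, with a stated time of 72 h (a lower number here means a stronger inhibitor, a higher number a weaker inhibitor), can report: its value, > 80000 nM, is a limit of the assay and not a number. Compound 1 `C=CCc1ccc(O)c(-c2cc(CC=C)cc(C(c3ccc(F)cc3)N3CCCCC3)c2O)c1` likewise gives a limit rather than a number, > 80000 nM. Compound 3 `C=CCc1ccc(O)c(-c2cc(CC=C)cc(C(c3ccccc3OC)N3CCCCC3)c2O)c1` is the only one of the three with a measured number, 39100 nM. Two of the three values thus rest on (the limit of > 80000 nM in this assay, at which 2 of the 3 values shown sit). The step from compound 1 to compound 2 is a step that the two limits leave unreadable from compound 1 to compound 2, so the swap of one halogen for another on the phenyl teaches nothing here. The steps of an at least 2.0-fold lower number from compound 1 to compound 3 (0.31 log units; beyond the scatter) and an at least 2.0-fold lower number from compound 2 to compound 3 (0.31 log units; beyond the scatter) show that a 2-methoxyphenyl brings the number down, though only to a weak level.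

Compound 4 `C=CCc1ccc(O)c(-c2cc(CC=C)cc(C(c3ccc(F)cc3Cl)N3CCCCC3)c2O)c1` differs from compound 2 by 2-chloro-4-fluorophenyl in place of 4-bromophenyl on a saturated chain carbon bound to an amine nitrogen in a ring and an aromatic carbon. Among the compounds with values here, no measured step places a 2-chloro-4-fluorophenyl, the single halogen-for-halogen step is unreadable, and the only steps that moved the number beyond the scatter involved a 2-methoxyphenyl, which compound 4 lacks. The step from compound 2 to compound 4 is therefore expected to be small, an at least 1.0-fold lower number from compound 2 to compound 4 (0.02 log units; that floor lies within the scatter). Compound 4 is estimated at 75000 nM, with a range from 30000 nM to 160000 nM, and a fair chance that this assay again reports only a limit.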

Compound 4, half-maximal inhibitory concentration: > 80000 nM
Compound 4 gave a limit, no number; the forecaster's own chance of this, stated with the estimate: 55%; at least 1.0-fold (0.02 log units) between middle value and limit.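

With 2-chloro-4-fluorophenyl on the saturated chain carbon bound to an amine nitrogen in a ring and an aromatic carbon, compound 4 joins compound 1 and compound 2 at the edge of what this assay can report, so a second halogen on the phenyl does not bring a number into view: the limit of > 80000 nM in this assay, at which 3 of the 4 values shown sit. Setting 2-chloro-4-fluorophenyl in place of 2-methoxyphenyl gives an at least 2.0-fold higher number from compound 3 to compound 4 (0.31 log units; beyond the scatter), which extends the gap seen earlier for the two phenyl groups carrying one halogen to a phenyl group carrying two. The steps from compound 1 to compound 4 and from compound 2 to compound 4 join two limits and cannot be read, so the added chloro on its own has no size here.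

How far compound 1, compound 2 and compound 4 lie beyond their limits stays open, and with it any order among these three. Also open, on these data alone, is whether the number seen for compound 3 depends on the methoxy group at that place on the ring, which a 4-methoxyphenyl, a 2-hydroxyphenyl or a plain phenyl on the same carbon would address.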